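This account rests on a few compounds, and the source may have more. Where it says the series, first, only, none or still open, it means among the compounds named here.

In a functional assay on RT-112 cells (Homo sapiens) for antiproliferative activity, read by MTT assay, with a stated time of 72 h (a lower number here means a stronger inhibitor of growth, a higher number a weaker inhibitor of growth), compound 1 `COc1cc(Nc2ncnc3c(NC(=O)Nc4ccccc4Cl)cccc23)cc(OC)c1` gives 356 nM and compound 2 `COc1cc(Nc2ncnc3c(NC(=O)Nc4cccc(Cl)c4Cl)cccc23)cc(OC)c1` gives 63.2 nM as its value, a modest step of a 5.6-fold lower number from compound 1 to compound 2 (0.75 log units; beyond the scatter) on adding one chloro group. Compound 3 `COc1cc(Nc2ncnc3c(NC(=O)Nc4ccc(Cl)c(C(F)(F)F)c4)cccc23)cc(OC)c1` reads > 20000 nM here, which is a limit and not a number (the limit of > 20000 nM in this assay, at which 1 of the 3 values shown sits). Compound 4 `COc1cc(Nc2ncnc3c(NC(=O)Nc4ccc([N+](=O)[O-])cc4)cccc23)cc(OC)c1` differs from compound 3 by 4-nitrophenyl in place of 4-chloro-3-(trifluoromethyl)phenyl on an amide-type nitrogen in words, 4-nitrophenyl in place of 4-chloro-3-(trifluoromethyl)phenyl on an amide-type nitrogen. For the measured compounds named here, the steps that bear on this are the two made at that same place, an at least 56-fold higher number from compound 1 to compound 3 (1.74 log units; beyond the scatter) and an at least 310-fold higher number from compound 2 to compound 3 (2.50 log units; beyond the scatter), both large, so a large step to a lower number is expected, although a second limit remains possible. The estimated step is an at least 5.0-fold lower number from compound 3 to compound 4 (0.69 log units; beyond the scatter) in that direction. For compound 4 the expected value is 4000 nM with an estimated range from 300 nM to 20000 nM in this assay at this stage.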

Compound 4, concentration for 50% growth inhibition: > 20000 nM
Compound 4: no number, only a limit; the forecaster's own chance of this, stated with the estimate: 35%; middle value at least 5.0-fold (0.69 log units) away from the limit.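

With 4-nitrophenyl on the amide-type nitrogen, the loss seen with 4-chloro-3-(trifluoromethyl)phenyl recurs with a second, different group, giving an at least 310-fold higher number from compound 2 to compound 4 (2.50 log units; beyond the scatter) and an at least 56-fold higher number from compound 1 to compound 4 (1.74 log units; beyond the scatter). So the two chlorophenyl compounds, not one outlier, now stand apart at this position. Compound 4 gives no number in this assay, only a limit, and the step between it and compound 3 cannot be read: the limit of > 20000 nM in this assay, at which 2 of the 4 values shown sit.

The compounds shown leave open how far either compound lies past that limit. They also leave open whether an amine or a carboxylic acid in place of the nitro group would bring back a measurable value.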